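A few compounds are considered here, and "the series" means these few. Any claim that something is new, unique, unknown or untested is made for them only; others in the source may bear on it.

Measured so far in an ADME assay on microsomes from liver (Mus musculus) for metabolic stability, using NADPH, with a stated time of 60 min; on this read-out higher numbers stand for fast clearance and lower numbers for slow clearance:

Compound 1 `O=C(Nc1ccc(F)c(C(F)(F)F)c1)Nc1ccccn1`: 705 uL/min
Compound 2 `O=C(Nc1cccc(C(=O)O)c1)Nc1ccc(F)c(C(F)(F)F)c1`: < 7 uL/min, which is a limit of the assay and not a number
Compound 3 `N#Cc1ccc(NC(=O)Nc2ccc(F)c(C(F)(F)F)c2)cc1`: 12 uL/min

Among the two numbers given, compound 1 stands highest in this assay. Compound 3 sits far lower, a gap well beyond the usual scatter of repeated measurements. For compound 2 the assay reports only (the limit of < 7 uL/min in this assay, at which 1 of the 3 values shown sits), so no number is known for it. All three share the same core; they differ only in the group carried on one amide-type nitrogen.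

The next compound to be run in this assay is compound 4 `Cc1cc(NC(=O)Nc2ccc(F)c(C(F)(F)F)c2)on1`. Starting from compound 1, the change is 3-methyl-1,2-oxazol-5-yl in place of pyridin-2-yl on an amide-type nitrogen. Among the measured compounds shown here, no pair of measured compounds carries this same change, so its effect can only be estimated. Seen against the spread between compound 1 and compound 3, the step is expected to run downward, toward slower clearance, as a 4.7-fold lower number from compound 1 to compound 4 (0.67 log units; beyond the scatter). Compound 4 is therefore expected to give about 150 uL/min in this assay, with a range of 40 uL/min to 600 uL/min.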

Compound 4, intrinsic clearance in a liver preparation (reported as CLH), per the amount of preparation that the assay uses: 108 uL/min
Beside the measured number, compound 4's estimate is 1.4-fold (0.14 log units) above it; the measured number falls inside the stated range.
By their numbers in this assay, from the lowest: compound 3; then compound 4; then compound 1. At a limit, below all of these: compound 2.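

Swapping one aromatic ring for another on this amide-type nitrogen is enough to shift the read-out in this assay: putting 3-methyl-1,2-oxazol-5-yl in place of pyridin-2-yl gives a 6.5-fold lower number from compound 1 to compound 4 (0.81 log units; beyond the scatter), a step beyond the scatter. The two groups have the same count of heavy atoms, so this change does not alter that count, yet the ring goes from six-membered with one hetero atom to five-membered with two. Nothing shown here explains why the number falls.

As far as these compounds go, what the same ring would give without its methyl group, or with an ethyl group in its place, stays open. So does the effect of an amine carried on the pyridin-2-yl ring of compound 1.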